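Methyl on the chain carbon of the benzyloxymethyl amine series

A few compounds are considered here, and "the series" means these few. Any claim that something is new, unique, unknown or untested is made for them only; others in the source may bear on it.

Measured compounds and their values in a functional assay on SMMC-7721 cells (Homo sapiens) for cytotoxicity, read by MTT assay, with a stated time of 72 h; on this read-out higher numbers stand for weaker inhibition and lower numbers for stronger inhibition:
compound 1 `COc1ccc2c(c1)[n+]([O-])nc(NCOC(C)c1ccccc1)[n+]2[O-]` gives 8040 nM
compound 2 `[O-][n+]1nc(NCOCc2ccccc2)[n+]([O-])c2ccccc21` gives 20100 nM
compound 3 `COc1ccc(COCNc2n[n+]([O-])c3ccccc3[n+]2[O-])cc1` gives 22000 nM

Compound 2 stands second highest of the three numbers in this assay. Going by the values given here, its nearest neighbour is compound 3, whose value lies within the scatter of compound 2; the step of a 1.1-fold higher number from compound 2 to compound 3 (0.04 log units; within the scatter) is the only single-point change measured so far, and it shows no effect beyond the scatter. The furthest number is that of compound 1, which differs from compound 2 in two places at once and is lower by a margin beyond the scatter.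

The next compound is compound 4 `CC(OCNc1n[n+]([O-])c2ccccc2[n+]1[O-])c1ccccc1`. It differs from compound 2 in one place: methyl in place of hydrogen on a saturated chain carbon bound to an aromatic carbon and an oxygen on a saturated carbon. Among the compounds with values here, no measured step bears directly on this change. Compound 1 carries the same methyl on the same saturated chain carbon together with a methoxy on the core, and its lower value sets a rough lower bound for what the methyl alone might give. Since the step of a 1.1-fold higher number from compound 2 to compound 3 (0.04 log units; within the scatter) shows that one added group left this assay unchanged, the methyl may equally well do nothing.

The expected step is a 1.5-fold lower number from compound 2 to compound 4 (0.19 log units; within the scatter), a modest move towards a lower number. Compound 4 is estimated at 13000 nM, within a range of 5000 nM to 30000 nM.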

Compound 4, half-maximal inhibitory concentration: 12900 nM
Estimate against measurement, compound 4: 1.0-fold (0.00 log units) above; the range from low to high includes it.
By their numbers in this assay, from the lowest: compounds 1, 4, 2 and 3 (each within the scatter of the next, the first and the last beyond it).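

In this assay, methyl in place of hydrogen on this saturated chain carbon now has a direct reading, a 1.6-fold lower number from compound 2 to compound 4 (0.19 log units; within the scatter), so the methyl alone does not move the number beyond the scatter on the core without methoxy. The second new step, a 1.6-fold higher number from compound 1 to compound 4 (0.21 log units; within the scatter), shows that the methoxy on the core of compound 1 likewise has no effect beyond the scatter when it is the only difference, so neither change alone accounts for a shift beyond the scatter in this small set. Methoxy in place of hydrogen on an aromatic carbon also reads alike in the two settings shown, with no difference beyond the scatter between them: the same change on two cores in this assay, a 1.1-fold higher number (0.04 log units; within the scatter) from compound 2 to compound 3 and a 1.6-fold lower number (0.21 log units; within the scatter) from compound 4 to compound 1, 1.8-fold (0.24 log units) apart, within the scatter of two such steps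

The compounds shown leave open whether this chain carbon tolerates anything larger or different from methyl, such as an ethyl group, a longer chain or an amine, and whether any of these would give a step beyond the scatter. They also leave open whether the two mirror-image forms of compound 4, which carries a methyl on this carbon, would read alike in this assay.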